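Swapping Methoxy for Chloro on the Pendant Phenyl

This account rests on a few compounds, and the source may have more. Where it says the series, first, only, none or still open, it means among the compounds named here.

Compound 1 `O=C1N=C(N2N=C(c3ccccc3)CC2c2ccccc2O)S/C1=C1/C(=O)Nc2ccccc21`: 2050 nM
Compound 2 `COc1ccc(C2CC(c3ccccc3)=NN2C2=NC(=O)/C(=C3\C(=O)Nc4ccccc43)S2)cc1`: 1520 nM

In a functional assay on cells (Cancer cell lines, Homo sapiens) for cytotoxicity, read by sulforhodamine B assay, with a stated time of 48 h (a higher number here means a weaker inhibitor of growth, a lower number a stronger inhibitor of growth), compound 2 has the lower of the two numbers, but a 1.3-fold lower number from compound 1 to compound 2 (0.13 log units; within the scatter) is within the scatter, so compound 2 and compound 1 cannot be told apart. Compound 3 `O=C1N=C(N2N=C(c3ccccc3)CC2c2ccc(Cl)cc2)S/C1=C1/C(=O)Nc2ccccc21` differs from compound 2 by chloro in place of methoxy on an aromatic carbon. Among the measured compounds shown here, the one measured step bearing on this, a 1.3-fold lower number from compound 1 to compound 2 (0.13 log units; within the scatter), also swapped the group attached to a saturated ring carbon and stayed within the scatter. The step of a 1.1-fold higher number from compound 2 to compound 3 (0.05 log units; within the scatter) is therefore expected to be none beyond the scatter. Compound 3 is expected to give about 1700 nM, with a range from 700 nM to 4000 nM.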

Compound 3, concentration for 50% growth inhibition: 250 nM
The estimate for compound 3 lay 6.8-fold (0.83 log units) above the measured number; measured number outside the range, below it.
By their numbers in this assay, from the lowest: compound 3; then compounds 2 and 1 (each within the scatter of the next).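

In this assay this place on the pendant phenyl does respond to its group: chloro in place of methoxy gives a 6.1-fold lower number from compound 2 to compound 3 (0.78 log units; beyond the scatter) and so moves beyond the scatter, unlike the earlier change. The 4-chlorophenyl group also stands apart from 2-hydroxyphenyl, with an 8.2-fold lower number from compound 1 to compound 3 (0.91 log units; beyond the scatter) in the same direction. Nothing available here explains this difference.

Open, as far as these compounds go, is whether the gain is particular to chloro or is shared by other groups at this place, such as bromo, methyl or an amine.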